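A few compounds are considered here, and "the series" means these few. Any claim that something is new, unique, unknown or untested is made for them only; others in the source may bear on it.

In this assay, among the measured compounds shown here, a physicochemical assay for lipophilicity, read by HPLC, measured as chromatographic lipophilicity, at pH 7.4 (on this read-out lower numbers stand for lower lipophilicity and higher numbers for higher lipophilicity), compound 1 `O=C(C1CCN(c2ccncn2)CC1)N1N=CC[C@H]1c1ccccc1` gives 3.2, the lowest of the three numbers measured so far. Compound 3 `Cc1nnc(N2CCC(C(=O)N3N=CC[C@H]3c3cc(F)cc(F)c3)CC2)o1` gives 3.6, a step above compound 1 that lies beyond the usual scatter, and compound 2 `O=C(C1CCCCC1)N1N=CCC1c1ccccc1` gives 5.9, the furthest from compound 1 of the three. Compound 4 `O=C(c1cnco1)N1CCC(C(=O)N2N=CC[C@H]2c2ccccc2)CC1` has not yet been measured; it differs from compound 1 in one place: (1,3-oxazol-5-yl)carbonyl in place of pyrimidin-4-yl on an amine nitrogen in a ring. For the measured compounds named here, no pair of measured compounds shows this change, so the expectation rests on compound 1 alone. Compound 4 is expected to sit below compound 1 by a modest step, a number 0.50 log units lower from compound 1 to compound 4 (beyond the scatter), just beyond the scatter. In this assay compound 4 is therefore estimated at 2.7, with a range from 2.1 to 3.3.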

Compound 4, distribution coefficient: 2.7
The estimate for compound 4 equals the measured number at the digits printed, and the stated range covers the measured number.
By their numbers in this assay, from the lowest: compound 4; then compound 1; then compound 3; then compound 2.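

In this assay the position on the amine nitrogen in the ring now has its first reading: (1,3-oxazol-5-yl)carbonyl in place of pyrimidin-4-yl gives a number 0.50 log units lower from compound 1 to compound 4 (beyond the scatter). The change replaces a six-membered aromatic ring with a five-membered one and adds a carbonyl, so both differ at once in this single pair. Nothing shown here gives a reason for the step.

As far as these compounds go, whether the carbonyl or the ring carries the step remains open. An acetyl group on the same nitrogen would help to separate the two.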